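The source may hold more compounds than are shown below. What is called first, only, known or untested is meant among the compounds shown, and "the series" means these compounds.

Measured so far in a functional assay on MIA PaCa-2 cells (Homo sapiens) for inhibition, read by MTT assay; a lower number here means a stronger inhibitor, a higher number a weaker inhibitor
Compound 1 `COc1ccccc1NC(=O)c1cc2cnc(Nc3ccc(N4CCNCC4)cn3)nc2n1C1CCCC1` gives 1830 nM
Compound 2 `COc1ccc(NC(=O)c2cc3cnc(Nc4ccc(N5CCNCC5)cn4)nc3n2C2CCCC2)c(OC)c1` gives 2230 nM
Compound 3 `O=C(Nc1ccccc1Cl)c1cc2cnc(Nc3ccc(N4CCNCC4)cn3)nc2n1C1CCCC1` gives 2170 nM

Compound 3 stands together with the other two, with a 1.0-fold lower number from compound 2 to compound 3 (0.01 log units; within the scatter) and a 1.2-fold higher number from compound 1 to compound 3 (0.07 log units; within the scatter) as its gaps. Compound 4 `Cc1ccccc1NC(=O)c1cc2cnc(Nc3ccc(N4CCNCC4)cn3)nc2n1C1CCCC1` differs from it by methyl in place of chloro on an aromatic carbon, ortho to a large group methyl in place of chloro on an aromatic carbon and nothing else. Among the measured compounds shown here, no measured step makes this exact swap. The closest evidence is a 1.2-fold higher number from compound 1 to compound 3 (0.07 log units; within the scatter) for chloro in place of methoxy, and a 1.2-fold higher number from compound 1 to compound 2 (0.09 log units; within the scatter) for an added methoxy on the same aromatic ring. Neither step leaves the scatter, so no step beyond the scatter is expected in this assay here. Compound 4 is estimated at 2000 nM with 1100 nM to 3600 nM as its expected range. This estimate means a 1.1-fold lower number from compound 3 to compound 4 (0.04 log units; within the scatter) as the expected step.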

Compound 4, half-maximal inhibitory concentration: 2500 nM
Beside the measured number, compound 4's estimate is 1.3-fold (0.10 log units) below it; low and high end bracket the measured number.
By their numbers in this assay, from the lowest: compounds 1, 3, 2 and 4 (each within the scatter of the next).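

In this assay, methyl at this place on the ring, ortho to a large group, reads the same as the groups before it: a 1.2-fold higher number from compound 3 to compound 4 (0.06 log units; within the scatter), a 1.4-fold higher number from compound 1 to compound 4 (0.14 log units; within the scatter) and a 1.1-fold higher number from compound 2 to compound 4 (0.05 log units; within the scatter). Chloro, methoxy and now methyl have therefore all been carried here without any step leaving the scatter, so this change adds a third group to that flat picture. Nothing measured here speaks to why these groups read alike. Still open, on these data alone, is whether an amine, a carboxylic acid or a longer chain such as butyl at this place would give a step beyond the scatter.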